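From 4-methoxyphenyl to furan-3-yl on the shared core

This account rests on a few compounds, and the source may have more. Where it says the series, first, only, none or still open, it means among the compounds named here.

Compound 1 `Nc1ncnn2c([C@@H]3O[C@H](CO)[C@@H](O)[C@H]3O)cc(-c3ccccc3)c12` gives > 100000 nM in a functional assay on NCI-H460 cells (Homo sapiens) for antiproliferative activity, with a stated time of 72 h (on this read-out lower numbers stand for stronger inhibition and higher numbers for weaker inhibition), which is a limit of the assay and not a number. Compound 2 `Nc1ncnn2c([C@@H]3O[C@H](CO)[C@@H](O)[C@H]3O)cc(-c3ccc(F)cc3)c12` gives 55500 nM. Compound 3 `COc1ccc(-c2cc([C@@H]3O[C@H](CO)[C@@H](O)[C@H]3O)n3ncnc(N)c23)cc1` gives 69300 nM, and these two values lie within the scatter of each other, as a 1.2-fold higher number from compound 2 to compound 3 (0.10 log units; within the scatter) shows. Compound 3 therefore stands level with compound 2, and both carry weak activity on this read-out.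

Compound 4 `Nc1ncnn2c([C@@H]3O[C@H](CO)[C@@H](O)[C@H]3O)cc(-c3ccoc3)c12` has furan-3-yl in place of 4-methoxyphenyl on an aromatic carbon of the shared core: furan-3-yl in place of 4-methoxyphenyl on an aromatic carbon.

For the measured compounds named here, three measured steps bear on this change, and all of them alter only a substituent on the phenyl ring. They are an at least 1.8-fold lower number from compound 1 to compound 2 (0.25 log units; that floor lies within the scatter), an at least 1.4-fold lower number from compound 1 to compound 3 (0.15 log units; that floor lies within the scatter) and a 1.2-fold higher number from compound 2 to compound 3 (0.10 log units; within the scatter). The first two are floors rather than sizes. Going by the values given here, no measured step replaces the phenyl ring itself, so the evidence is indirect and the range must stay wide. The small step for compound 3 in a 1.2-fold higher number from compound 2 to compound 3 (0.10 log units; within the scatter) gives no ground for expecting a large shift, though a modest move toward a lower number is plausible. The expected step is a 2.0-fold lower number from compound 3 to compound 4 (0.30 log units; within the scatter). Compound 4 is estimated at 35000 nM, with an expected range of 4000 nM to 100000 nM.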

Compound 4, half-maximal inhibitory concentration: 1500 nM
For compound 4 the middle estimate is 23-fold (1.37 log units) above the measured one, outside the stated range (below it).
By their numbers in this assay, from the lowest: compound 4; then compounds 2 and 3 (each within the scatter of the next). At a limit, above all of these: compound 1.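

For the compounds shown here, at this position on the shared core, the nature of the aromatic ring itself counts for far more in this assay than the substituent on a phenyl ring: the only exact step among the phenyl compounds stays within the scatter (a 1.2-fold higher number from compound 2 to compound 3 (0.10 log units; within the scatter)), while furan-3-yl opens a large gap to both substituted phenyl compounds (a 46-fold lower number from compound 3 to compound 4 (1.66 log units; beyond the scatter) and a 37-fold lower number from compound 2 to compound 4 (1.57 log units; beyond the scatter)). Set against the unsubstituted phenyl ring, the change is again large, and its true size is not fixed (an at least 66-fold lower number from compound 1 to compound 4 (1.82 log units; beyond the scatter)). Compound 1 gives only a limit of the assay, so this step is a floor: the limit of > 100000 nM in this assay, at which 1 of the 4 values shown sits.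

The swap of 4-methoxyphenyl for furan-3-yl replaces a six-membered aromatic ring of carbon only with a smaller ring that carries a hetero atom, and the compounds shown cannot separate ring size from the ring oxygen or from the loss of the methoxy group. Going by these compounds, whether the gain persists with furan-2-yl, thiophen-3-yl or a non-aromatic group such as a short alkyl chain or an amine remains open, as does whether it extends beyond this one cell line.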